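The source may hold more compounds than are shown below. What is called first, only, known or untested is meant among the compounds shown, and "the series" means these compounds.

Compound 1 `Cc1nc(S(C)(=O)=O)ccc1Oc1ncnc(OC2CCN(C(=O)OC(C)(C)CF)CC2)c1F` gives 95% in a functional assay on isolated protein for inhibition of Glucose-dependent insulinotropic receptor (Rattus norvegicus), read by HTRF and cAMP accumulation; a lower number here means a smaller maximal response, a higher number a larger maximal response. Compound 2 `Cc1nc(S(C)(=O)=O)ccc1Oc1ncnc(OC2CCN(C(=O)OC3(C(F)(F)F)CCC3)CC2)c1F` gives 82%. Compound 3 `Cc1nc(S(C)(=O)=O)ccc1Oc1ncnc(OC2CCN(C(=O)SC3CC3)CC2)c1F` gives 80%.

Compound 3 stands lowest of the three numbers, though its nearest neighbour, compound 2, is within the scatter of it, and only compound 1 lies clearly higher: the step of a number 15 percentage points lower from compound 1 to compound 3 (beyond the scatter) is beyond the scatter, while a number 2 percentage points lower from compound 2 to compound 3 (within the scatter) is not. The change to compound 4 `Cc1nc(S(C)(=O)=O)ccc1Oc1ncnc(OC2CCN(C(=O)C(C)(F)F)CC2)c1F` is a group of 4 heavy atoms (2 carbon, 2 fluorine; no ring) in place of a group of 4 heavy atoms (3 carbon, 1 sulfur; one three-membered non-aromatic ring of carbon only), on a carbonyl carbon. Going by the values given here, two measured steps bear on this position on the carbonyl carbon: a number 15 percentage points lower from compound 1 to compound 3 (beyond the scatter) and a number 2 percentage points lower from compound 2 to compound 3 (within the scatter), with a number 13 percentage points lower from compound 1 to compound 2 (beyond the scatter) showing that the three groups tried so far spread over a modest range. The group entering in compound 4 resembles none of them closely, so no large step is expected in this assay; a small rise or none beyond the scatter seems most likely, giving an expected step of a number 5 percentage points higher from compound 3 to compound 4 (within the scatter). Compound 4 is therefore estimated at 85%, with a range from 70% to 100%.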

Compound 4, largest response reached (reported as efficacy), in percent of the reference or control that the assay uses: 87%
Estimate against measurement, compound 4: 2 percentage points below; the measured number falls inside the stated range.
By their numbers in this assay, from the lowest: compounds 3, 2, 4 and 1 (each within the scatter of the next, the first and the last beyond it).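

In this assay, 1,1-difluoroethyl on the carbonyl carbon cannot be told apart from any of the three earlier groups: a number 7 percentage points higher from compound 3 to compound 4 (within the scatter), a number 5 percentage points higher from compound 2 to compound 4 (within the scatter) and a number 8 percentage points lower from compound 1 to compound 4 (within the scatter). All three earlier groups reach the carbonyl carbon through oxygen or sulfur, so compound 4 shows that a group attached through carbon at this place, with no ring, still keeps the maximal response within the scatter of each of them, even though compound 1 and compound 3 lie beyond the scatter of each other. No measurement is available to explain this result.

Going by these compounds, whether an amine or an unfluorinated ethyl on the same carbonyl carbon would keep the response remains open. So does whether the two fluorines of the 1,1-difluoroethyl group matter at all.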